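This account rests on a few compounds, and the source may have more. Where it says the series, first, only, none or still open, it means among the compounds named here.

Of the compounds shown here, three built on one shared core have been tested in a functional assay on HL-60 cells (Homo sapiens) for antiproliferative activity, read by XTT assay, with a stated time of 72 h; a lower number here means a stronger inhibitor, a higher number a weaker inhibitor. Compound 1 `COc1ncnc2c1c(-c1ccoc1)cn2[C@@H]1O[C@H](CO)[C@@H](O)[C@H]1O` gives 150 nM. Compound 2 `COc1ncnc2c1c(-c1cccs1)cn2[C@@H]1O[C@H](CO)[C@@H](O)[C@H]1O` gives 80 nM, the lowest of the two numbers obtained, with compound 1 the nearest to it. Compound 3 `COc1ncnc2c1c(-c1ccccc1)cn2[C@@H]1O[C@H](CO)[C@@H](O)[C@H]1O` reaches only > 20000 nM, which is a limit of the assay rather than a number (the limit of > 20000 nM in this assay, at which 1 of the 3 values shown sits). The steps seen so far, a 1.9-fold lower number from compound 1 to compound 2 (0.27 log units; within the scatter), an at least 130-fold higher number from compound 1 to compound 3 (2.12 log units; beyond the scatter) and an at least 250-fold higher number from compound 2 to compound 3 (2.39 log units; beyond the scatter), all alter the aryl group on the shared core. Compound 4 `CSc1ncnc2c1c(-c1cccs1)cn2[C@@H]1O[C@H](CO)[C@@H](O)[C@H]1O` differs from compound 2 at another place: methylsulfanyl in place of methoxy on an aromatic carbon. For the measured compounds named here, no measured step touches this place, so no step beyond the scatter is expected, no change at the digits printed from compound 2 to compound 4 (within the scatter). Compound 4 is therefore estimated at 80 nM, between 25 nM and 250 nM.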

Compound 4, half-maximal inhibitory concentration: 1130 nM
Beside the measured number, compound 4's estimate is 14-fold (1.15 log units) below it; the measured number lies above the stated range.
By their numbers in this assay, from the lowest: compounds 2 and 1 (each within the scatter of the next); then compound 4. At a limit, above all of these: compound 3.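

For the compounds shown here, the position on the six-membered aromatic ring, untouched by the earlier steps, proves sensitive: in this assay, methylsulfanyl in place of methoxy gives a 14-fold higher number from compound 2 to compound 4 (1.15 log units; beyond the scatter). Going by these compounds alone, the aryl group is therefore not the only part of the compounds that moves the number, and a change of oxygen to sulfur is enough, though the two groups match in their counts of heavy atoms and hydrogen-bond acceptors. Nothing shown gives a reason for this step. As far as these compounds go, how an amine or an ethoxy group would fare at this place remains open. So does whether the same change would have a similar effect alongside the furan-3-yl group of compound 1.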